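This account rests on a few compounds, and the source may have more. Where it says the series, first, only, none or still open, it means among the compounds named here.

Compound 1 `O=C(Nc1ccc(Oc2ccnc3[nH]ccc23)cc1)c1ccc(-c2ccc(Cl)cc2)cn1` was tested in a functional assay on A549 cells (Homo sapiens) for cytotoxicity, read by MTT assay, with a stated time of 72 h; a lower number here means a stronger inhibitor, a higher number a weaker inhibitor. In this assay compound 1 gives > 10000 nM, which is a limit of the assay and not a number. Compound 2 `O=C(Nc1ccc(Oc2ccnc3[nH]ccc23)cc1)c1ccc(-c2ccc(F)cc2F)cn1` differs from compound 1 by carrying 2,4-difluorophenyl in place of 4-chlorophenyl on an aromatic carbon. In this assay compound 2 gives > 10000 nM, again a limit. The step that the two limits leave unreadable from compound 1 to compound 2 therefore cannot be read because both ends sit at the limit of > 10000 nM in this assay, at which 2 of the 3 values shown sit. For the measured compounds named here, compound 3 `O=C(Nc1ccc(Oc2ccnc3[nH]ccc23)cc1)c1cc(-c2ccc(Cl)cc2)ccn1` is the one member of the set that yields a number: in this assay compound 3 gives 4310 nM.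

Compound 4 `O=C(Nc1ccc(Oc2ccnc3[nH]ccc23)c(F)c1)c1ccc(-c2ccc(Cl)cc2)cn1` has not yet been measured. It differs from compound 1 by fluoro in place of hydrogen on an aromatic carbon. Going by the values given here, no measured step touches this position, and the only measured step starting from compound 1 is unreadable, so the expectation for compound 4 rests on where compound 1 stands. Compound 4 is expected to come out near 12000 nM, in a range from 4000 nM to 40000 nM, most likely reported again as a limit. The expected step that the limit leaves unreadable from compound 1 to compound 4 is accordingly small.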

Compound 4, half-maximal inhibitory concentration: 10000 nM
The estimate for compound 4 lay 1.2-fold (0.08 log units) above the measured number; the range from low to high includes it.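

The earlier compounds shown here varied only the aryl group at the far end of the core, whereas here the change is fluoro in place of hydrogen on an aromatic carbon, ortho to a large group and meta to a large group, and in this assay compound 4 gives 10000 nM, a number and not a limit, which makes the step of a number no higher from compound 1 to compound 4 (the limit leaves the size open). Compound 1 gives > 10000 nM, which is a limit of the assay. The figure of compound 4 coincides with that limit, so the step cannot be read and no gain in potency can be claimed, because the parent stands at the edge of the assay's range: the limit of > 10000 nM in this assay, at which 2 of the 4 values shown sit.

The compounds shown leave open whether a larger group at this position, such as chloro, methoxy or an amine, would give a clearer reading. For the compounds shown here, they also leave open what fluoro would do on compound 3, the one earlier compound with a readable number.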